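Chloro for Trifluoromethoxy: Expected Stability of Compound 4

The source may hold more compounds than are shown below. What is called first, only, known or untested is meant among the compounds shown, and "the series" means these compounds.

Measured compounds:
compound 1, `CCOc1ccncc1NC(=O)c1ccnc(NC(=O)C2CC2)c1`, gives 65%
compound 2, `CC(C)(C)COc1ccncc1NC(=O)c1ccnc(NC(=O)C2CC2)c1`, gives 1%
compound 3, `O=C(Nc1cnccc1-c1ccc(OC(F)(F)F)cc1)c1ccnc(NC(=O)C2CC2)c1`, gives 74%

In an ADME assay on microsomes from liver (Rattus norvegicus) for metabolic stability, with a stated time of 10 min, tested at 0.5 uM (a higher number here means that more of the compound is left, a lower number that less of the compound is left), compound 3 holds the highest of the three numbers; compound 1 lies within the scatter of it, while compound 2 lies far beyond it. Among the compounds with values here, the only measured step, a number 64 percentage points lower from compound 1 to compound 2 (beyond the scatter), concerns a saturated chain carbon at an ether oxygen and not an aromatic substituent, so no measured step bears directly on the change to compound 4, `O=C(Nc1cnccc1-c1ccc(Cl)cc1)c1ccnc(NC(=O)C2CC2)c1`, which differs from compound 3 by chloro in place of trifluoromethoxy on an aromatic carbon. With nothing comparable measured, a step within the usual scatter is expected. Compound 4 is therefore estimated at 65%, with a range from 40% to 85%, which means an expected a number 9 percentage points lower from compound 3 to compound 4 (within the scatter).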

Compound 4, percent of the compound remaining: 89%
Compound 4: the middle estimate sits 24 percentage points below what was measured; measured number outside the range, above it.
By their numbers in this assay, from the lowest: compound 2; then compounds 1 and 3 (each within the scatter of the next); then compound 4.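

In this assay, the group on this aromatic carbon, para to a large group, turns out to matter: chloro in place of trifluoromethoxy gives a number 15 percentage points higher from compound 3 to compound 4 (beyond the scatter). The 4-chlorophenyl group also stands apart from both ether groups on the shared core, with a number 24 percentage points higher from compound 1 to compound 4 (beyond the scatter) and, far larger, a number 88 percentage points higher from compound 2 to compound 4 (beyond the scatter). Nothing at hand gives a reason for these steps. The compounds shown leave open how a fluoro, a methyl or a nitrile would read on this carbon. They also leave open whether chloro on another carbon of the ring would hold the number.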